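Fluoro for Methyl: Expected Potency of Compound 3

The source may report more compounds than this note shows. Statements on the series, on what has been measured and on what is new or still open speak of the compounds shown alone.

Of the compounds shown here, two sharing one core have been measured in a functional assay on CHO cells for agonist activity at hydroxycarboxylic acid receptor 1 (Homo sapiens), read by cAMP accumulation; a higher number here means that more compound is needed for the effect, a lower number that less compound is needed. Compound 1 `CCOc1cc(Cl)c(C(=O)NC(=O)Nc2nc3ccc(S(=O)(=O)C4CCN(C)CC4)cc3s2)cc1-n1cccn1` gives 23 nM in this assay. Among the compounds with values here, compound 2 `Cc1cc(Cl)c(C(=O)NC(=O)Nc2nc3ccc(S(=O)(=O)C4CCN(C)CC4)cc3s2)cc1-n1cccn1` gives 6100 nM, the highest of the two numbers seen so far; the single measured step, a 270-fold higher number from compound 1 to compound 2 (2.42 log units; beyond the scatter), is large and lies beyond the scatter. Compound 3 `CN1CCC(S(=O)(=O)c2ccc3nc(NC(=O)NC(=O)c4cc(-n5cccn5)c(F)cc4Cl)sc3c2)CC1` is the next compound to be measured. It differs from compound 2 by fluoro in place of methyl on an aromatic carbon. Within the data shown here, no measured step exchanges a fluoro group for a methyl group at this position, so the only step that bears on the change is the one from compound 1 to compound 2, which shows that this position responds strongly to what is placed there. Since that step carries no information on fluoro itself, the direction is uncertain, and compound 3 is expected to show a modest change of a 2.0-fold lower number from compound 2 to compound 3 (0.31 log units; beyond the scatter) with a wide range. Compound 3 is estimated at 3000 nM, between 500 nM and 18000 nM.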

Compound 3, half-maximal effective concentration: 3600 nM
Compound 3: middle estimate off by 1.2-fold (0.08 log units), on the low side; the range from low to high includes it.
By their numbers in this assay, from the lowest: compound 1; then compounds 3 and 2 (each within the scatter of the next).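

In this assay, fluoro in place of methyl gives a 1.7-fold lower number from compound 2 to compound 3 (0.23 log units; within the scatter), so the two groups cannot be told apart on this carbon, which is ortho to the 1H-pyrazol-1-yl group and meta to the chloro group. The new comparison with compound 1 gives a 160-fold higher number from compound 1 to compound 3 (2.19 log units; beyond the scatter), a large step of the same direction as a 270-fold higher number from compound 1 to compound 2 (2.42 log units; beyond the scatter). The high number seen earlier is therefore not peculiar to methyl: among the three compounds, ethoxy alone stands apart, and both of the one-atom replacements give numbers far from that of compound 1.

The compounds shown leave open whether the oxygen attached to the ring or the ethyl chain beyond it accounts for the difference, a question on which methoxy, a longer propoxy chain or an amine at this position would bear. No measurement given here accounts for the gap between ethoxy and the two smaller groups, or for the closeness of methyl and fluoro.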